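The source may report more compounds than this note shows. Statements on the series, on what has been measured and on what is new or still open speak of the compounds shown alone.

In an ADME assay on MDCKII-LE cells (Canis lupus familiaris) for permeability, read by transwell migration, in the apical to basolateral direction (on this read-out lower numbers stand for lower permeability and higher numbers for higher permeability), compound 2 `NC(=O)[C@@H](CCC(F)(F)F)N(C[C@@H]1CCOC1)S(=O)(=O)c1ccc(Cl)cc1` gives 20.5 10^-6 cm/s as the higher of two numbers, against compound 1 `NC(=O)[C@@H](CCC(F)(F)F)N(CC1CCCC1)S(=O)(=O)c1ccc(Cl)cc1` with 6.01 10^-6 cm/s in that comparison. Compound 3 `NC(=O)[C@@H](CCC(F)(F)F)N(C[C@H]1CCCO1)S(=O)(=O)c1ccc(Cl)cc1` differs from compound 2 by oxolan-2-yl in place of oxolan-3-yl on a saturated chain carbon bound to a sulfonamide nitrogen with oxolan-2-yl in place of oxolan-3-yl on a saturated chain carbon bound to a sulfonamide nitrogen. Among the compounds with values here, the only measured step, a 3.4-fold higher number from compound 1 to compound 2 (0.53 log units; beyond the scatter) for oxolan-3-yl in place of cyclopentyl, is modest and involves a different exchange, so it bears only loosely. Compound 3 keeps the same atoms, joined differently, and no step beyond the scatter is expected in this assay here. The estimated change is a 1.0-fold lower number from compound 2 to compound 3 (0.01 log units; within the scatter) in all. Compound 3 is estimated at 20 10^-6 cm/s with an expected range from 10 10^-6 cm/s to 38 10^-6 cm/s in this measurement.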

Compound 3, apparent permeability in the MDCKII-LE assay: 19.1 10^-6 cm/s
Estimate against measurement, compound 3: 1.0-fold (0.02 log units) above, and the stated range covers the measured number.
By their numbers in the MDCKII-LE assay, from the lowest: compound 1; then compounds 3 and 2 (each within the scatter of the next).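

In the MDCKII-LE assay, oxolan-2-yl in place of oxolan-3-yl leaves the read-out level, a 1.1-fold lower number from compound 2 to compound 3 (0.03 log units; within the scatter), while the step from cyclopentyl stays beyond the scatter, a 3.2-fold higher number from compound 1 to compound 3 (0.50 log units; beyond the scatter). At this place, on a saturated chain carbon bound to a sulfonamide nitrogen, both oxolanes therefore stand clear of cyclopentyl. In a physicochemical assay for lipophilicity, read by HPLC, measured as octanol-water partition, at pH 7.4 (a higher number here means a more lipophilic compound, a lower number a more polar compound), compound 2 gives 2.8 and compound 3 gives 3.6. The two oxolanes still part in the physicochemical assay, with no matching shift in the permeability read-out: the measured distribution coefficient of compound 2, 2.8, and of compound 3, 3.6, a number 0.80 log units higher (beyond the scatter). Going by these compounds, whether an open-chain ether such as 2-methoxyethyl, or a morpholine ring, would hold this permeability at the same place remains open.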